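The compounds below may be only part of what the source reports. "The series", "measured", "known", "first", "only" and "open" are said of these compounds alone.

Measured compounds in a functional assay on K562 cells (Homo sapiens) for cytotoxicity, read by MTT assay, with a stated time of 48 h; on this read-out lower numbers stand for stronger inhibition and higher numbers for weaker inhibition:
- compound 1, `COc1ccc(-c2c[nH]c(=O)n2-c2cc(OC)c(OC)c(OC)c2)cc1N`: 49200 nM
- compound 2, `COc1ccc(-c2cn(C(=O)Nc3cc(OC)c(OC)c(OC)c3)c(=O)n2-c2cc(OC)c(OC)c(OC)c2)cc1`: 3800 nM
- compound 3, `COc1ccc(-c2cn(C(=O)Nc3cc(OC)c(OC)c(OC)c3)c(=O)n2-c2cc(OC)c(OC)c(OC)c2)cc1N`: 5800 nM

Compound 1 gives the highest number of the three in this assay; compound 3 stands nearest to it and compound 2 furthest, both beyond the scatter.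

The unmeasured compound 4, `COc1ccc(-c2cn(C(C)=O)c(=O)n2-c2cc(OC)c(OC)c(OC)c2)cc1N`, differs from compound 1 as follows: acetyl in place of hydrogen on an aromatic nitrogen. For the measured compounds named here, no measured step changes this aromatic nitrogen while holding everything else fixed. Going by the values given here, the only step on record, a 1.5-fold higher number from compound 2 to compound 3 (0.18 log units; within the scatter), concerns the amino group and says nothing about the ring nitrogen. What the values show is that compound 1, with hydrogen on that nitrogen, gives 49200 nM, whereas the compound that differs from compound 1 only at that nitrogen, compound 3, gives 5800 nM. Acetyl is a smaller group than the one in compound 3, so a step down in number, smaller than that gap and beyond the scatter, is expected: a 4.1-fold lower number from compound 1 to compound 4 (0.61 log units; beyond the scatter). Compound 4 is therefore estimated at 12000 nM in this assay, range 4000 nM to 40000 nM.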

Compound 4, half-maximal inhibitory concentration: 500 nM
Estimate against measurement, compound 4: 24-fold (1.38 log units) above, and the stated range ends above it.
By their numbers in this assay, from the lowest: compound 4; then compounds 2 and 3 (each within the scatter of the next); then compound 1.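

In this assay, the aromatic nitrogen proves to be a strong lever in its own right: acetyl in place of hydrogen gives a 98-fold lower number from compound 1 to compound 4 (1.99 log units; beyond the scatter), a large step beyond the scatter. Size of the group on this nitrogen does not track the number in the pair at hand: compound 3, with the larger group, gives 5800 nM, while compound 4, with acetyl, gives 500 nM. No data shown here explain this step.

Open, on these data alone, is whether the carbonyl is needed, which a plain methyl or a longer chain such as propionyl on this nitrogen would test. For the compounds shown here, also open is what the amino group does with acetyl in place, as its only step, a 1.5-fold higher number from compound 2 to compound 3 (0.18 log units; within the scatter), stands with the larger group on the nitrogen.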